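The source may hold more compounds than are shown below. What is called first, only, known or untested is meant among the compounds shown, and "the series" means these compounds.

In a functional assay on A2780 cells (Homo sapiens) for cytotoxicity, read by MTT assay, with a stated time of 48 h (a lower number here means a stronger inhibitor, a higher number a weaker inhibitor), compound 1 `CCn1cc(-c2nc3ccccc3[nH]2)c(=O)c2cc(F)c(N3CCNC(C)C3)c(F)c21` gives 11600 nM, compound 2 `CCn1cc(-c2nc3ccccc3o2)c(=O)c2cc(F)c(N3CCNC(C)C3)c(F)c21` gives 83500 nM and compound 3 `CCn1cc(-c2nc3ccccc3s2)c(=O)c2cc(F)c(N3CCNC(C)C3)c(F)c21` gives 9800 nM. Compound 3 therefore stands level with compound 1, as a 1.2-fold lower number from compound 1 to compound 3 (0.07 log units; within the scatter) shows, and clear of compound 2, as an 8.5-fold lower number from compound 2 to compound 3 (0.93 log units; beyond the scatter) shows. Compound 4 `CCn1cc(-c2nc3ccc([N+](=O)[O-])cc3s2)c(=O)c2cc(F)c(N3CCNC(C)C3)c(F)c21` carries nitro in place of hydrogen on an aromatic carbon. Going by the values given here, no measured step tests such a substitution. The nearest evidence is the exchange of the fused group on the shared core, which gave those steps and a 7.2-fold higher number from compound 1 to compound 2 (0.86 log units; beyond the scatter), so nothing larger than a modest step is expected in this assay and no direction is firmly indicated. The expected change is a 1.2-fold lower number from compound 3 to compound 4 (0.09 log units; within the scatter). For compound 4 the estimated value is 8000 nM, with an expected range from 2500 nM to 30000 nM.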

Compound 4, half-maximal inhibitory concentration: 3300 nM
The estimate for compound 4 lay 2.4-fold (0.38 log units) above the measured number, within the range that was stated.
By their numbers in this assay, from the lowest: compound 4; then compounds 3 and 1 (each within the scatter of the next); then compound 2.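

In this assay, nitro in place of hydrogen on an aromatic carbon of the six-membered ring of carbon only gives a 3.0-fold lower number from compound 3 to compound 4 (0.47 log units; beyond the scatter). The earlier compounds shown here varied only the fused group itself, whereas this step shows that a substituent on that group, here with 3 heavy atoms, is tolerated and moves the number beyond the scatter. Nothing measured here explains this step.

Going by these compounds, whether an amine or a carboxylic acid at this place would match nitro stays open. So does whether nitro would give a similar step on 1,3-benzoxazol-2-yl or 1H-benzimidazol-2-yl.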